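Cytotoxicity notes: amide side-chain swap in the series

The source may hold more compounds than are shown below. What is called first, only, known or untested is meant among the compounds shown, and "the series" means these compounds.

Compound 1 `NC(=O)[C@H](CCC(=O)O)NC(=O)C1(Cc2ccccc2)CCN1C(=O)OCc1ccccc1` and compound 2 `CC(C)[C@H](NC(=O)[C@@]1(Cc2ccccc2)CCN1C(=O)OCc1ccccc1)C(N)=O` share the same core and were both run in an ADME assay on HELF cells (Homo sapiens) for cytotoxicity, with a stated time of 3 days; on this read-out lower numbers stand for higher toxicity in this test and higher numbers for lower toxicity in this test. In this assay compound 1 gives > 100000 nM, which is a limit of the assay rather than a number. Compound 2 returns > 100000 nM in this assay, again only a limit. For the measured compounds named here, compound 2 thus stands where every value so far stands: the limit of > 100000 nM in this assay, at which 2 of the 2 values shown sit. Going by the values given here, no step between measured compounds is available, so nothing yet shows how a change on the amide-type nitrogen moves this read-out.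

Compound 3 `CC(C)CNC(=O)[C@H](C)NC(=O)[C@@]1(Cc2ccccc2)CCN1C(=O)OCc1ccccc1` has not been measured. It differs from compound 2 by 1-(isobutylcarbamoyl)ethyl in place of 1-carbamoyl-2-methylpropyl on an amide-type nitrogen. The step expected from this change is a number no higher from compound 2 to compound 3 (the limit leaves the size open), none beyond the scatter. Compound 3 is expected to return another limit in this assay, estimated at 100000 nM with a range from 50000 nM to 200000 nM.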

Compound 3, minimum cytotoxic concentration: > 100000 nM
Compound 3: no number, only a limit; the forecaster's own chance of this, stated with the estimate: 85%; the middle value sits exactly at the limit.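

In this assay compound 3 gives > 100000 nM, a limit and not a number. Compound 2 also stands at a limit, so no step can be read between compound 2 and compound 3. What stays open is whether any change on an amide-type nitrogen moves this read-out: the limit of > 100000 nM in this assay, at which 3 of the 3 values shown sit.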